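Nitrocatechol cyanoacrylamides: amide nitrogen substitution notes

The source may report more compounds than this note shows. Statements on the series, on what has been measured and on what is new or still open speak of the compounds shown alone.

Measured so far:
compound 1 `N#C/C(=C\c1cc(O)c(O)c([N+](=O)[O-])c1)C(=O)N(c1ccccc1)c1ccccc1`: > 100 ug/mL, a limit of the assay
compound 2 `COc1ccc(NC(=O)/C(C#N)=C/c2cc(O)c(O)c([N+](=O)[O-])c2)cc1`: 45.4 ug/mL
compound 3 `COc1c(O)ccc(/C=C(\C#N)C(=O)Nc2cccc(Cl)c2)c1[N+](=O)[O-]`: > 100 ug/mL, a limit of the assay

Among the compounds with values here, in a functional assay on BGC-823 cells (Homo sapiens) for antiproliferative activity, read by MTT assay (a higher number here means a weaker inhibitor, a lower number a stronger inhibitor), compound 2 gives 45.4 ug/mL, and this is the only number in the set. For compound 1 the assay reports only a limit, > 100 ug/mL. For compound 3 the assay likewise reports only a limit, > 100 ug/mL. So two of the three compounds sit at the limit of > 100 ug/mL in this assay, at which 2 of the 3 values shown sit, and only compound 2 yields a measurable value.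

Compound 4 `N#C/C(=C\c1cc(O)c(O)c([N+](=O)[O-])c1)C(N)=O` has not yet been measured in this assay. It differs from compound 2 in one place: hydrogen in place of 4-methoxyphenyl on an amide-type nitrogen, giving the unsubstituted amide. Within the data shown here, no step between measured compounds is available to calibrate this change. Among the measured compounds shown here, with compound 1 at > 100 ug/mL and compound 3 at > 100 ug/mL, the set shows only one compound that clears the limit, so the expectation is a step toward weaker inhibition, beyond the scatter, with a fair chance that compound 4 also returns only a limit. The expected step from compound 2 to compound 4 is a 1.8-fold higher number from compound 2 to compound 4 (0.25 log units; within the scatter). Compound 4 is thus estimated at 80 ug/mL, within 25 ug/mL to 250 ug/mL.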

Compound 4, half-maximal inhibitory concentration: > 100 ug/mL
Compound 4 ended at the assay's limit; the forecaster's own chance of this, stated with the estimate: 45%; middle value at least 1.2-fold (0.09 log units) from the limit.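

In this assay, within the data shown here, hydrogen in place of 4-methoxyphenyl on the amide-type nitrogen gives an at least 2.2-fold higher number from compound 2 to compound 4 (0.34 log units; beyond the scatter), the first change that can be read at a single place. At this position, the 4-methoxyphenyl group therefore goes with the measurable activity of compound 2, and the unsubstituted amide of compound 4 does not retain that activity within the range of the assay. Compound 4 gives only a limit of the assay, not a number, so the step is a lower bound and its full size cannot be read: the limit of > 100 ug/mL in this assay, at which 3 of the 4 values shown sit.

The compounds shown do not separate the contribution of the aromatic ring from that of its methoxy group, so a plain phenyl, a 4-hydroxyphenyl or a 4-fluorophenyl on this nitrogen would address a question that remains open. Also open, as far as these compounds go, is whether the nitrogen tolerates a non-aromatic substituent, such as a short alkyl chain, a benzyl group or a chain ending in an amine, and whether any of these would give a value stronger than that of compound 2.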